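The compounds below may be only part of what the source reports. "The series", "measured", "known", "first", "only" and "open" are said of these compounds alone.

Compound 1, `S=C(Nc1ccc(Cl)cc1)Nc1nc2ccccc2s1`, sits at a limit of a functional assay on U-937 cells (Homo sapiens) for cytotoxicity, read by MTT assay, with a stated time of 48 h (a lower number here means a stronger inhibitor, a higher number a weaker inhibitor), rather than at a number: > 50000 nM.
Compound 2, `Clc1ccc2nc(Nc3nc4ccccc4s3)sc2c1`, likewise sits at a limit in this assay: > 50000 nM.
Compound 3, `Fc1ccc2nc(NC(=S)Nc3ccc(Cl)cc3)sc2c1`, gives a number in this assay: 18700 nM.

Compound 2 thus stands at the edge of what this assay can report, a point shared by most of the values at hand (the limit of > 50000 nM in this assay, at which 2 of the 3 values shown sit). Compound 4, `CCOc1ccc2nc(Nc3nc4ccccc4s3)sc2c1`, differs from compound 2 by ethoxy in place of chloro on an aromatic carbon. Among the compounds with values here, the only measured step, an at least 2.6-fold lower number from compound 1 to compound 3 (0.42 log units; beyond the scatter), concerns a different change on a different core, so it bears only loosely on this one. With nothing measured for ethoxy in place of chloro, no shift beyond the scatter is expected, and the step from compound 2 to compound 4 is estimated at a number no higher from compound 2 to compound 4 (the limit leaves the size open). Compound 4 is therefore expected at 50000 nM, within 15000 nM to 150000 nM.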

Compound 4, half-maximal inhibitory concentration: > 50000 nM
Compound 4 was reported as a limit (the forecaster's own chance of this, stated with the estimate: 65%); the middle value sits exactly at the limit.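

Within the data shown here, compound 2 and compound 4 both sit at a limit in this assay and give no number, so no step between them can be read: the limit of > 50000 nM in this assay, at which 3 of the 4 values shown sit.

On these data alone, whether ethoxy in place of chloro changes the result at all remains open.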